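The compounds below may be only part of what the source reports. "The series", "measured", "known", "first", "only" and "open" are said of these compounds alone.

Compound 2 `Cc1cccc(CSc2n[nH]c(-n3[se]c4ccccc4c3=O)n2)c1` stands with the lowest of the two numbers measured in a functional assay on SMMC-7721 cells (Homo sapiens) for antiproliferative activity, read by CCK-8 assay, with a stated time of 48 h; on this read-out lower numbers stand for stronger inhibition and higher numbers for weaker inhibition; compound 2 gives 9040 nM. Compound 1 `CCSc1n[nH]c(-n2[se]c3ccccc3c2=O)n1` gives 10000 nM, and the step of a 1.1-fold lower number from compound 1 to compound 2 (0.04 log units; within the scatter) shows no separation beyond the scatter. Compound 3 `CCCSc1n[nH]c(-n2[se]c3ccccc3c2=O)n1` differs from compound 2 by ethyl in place of 3-methylphenyl on a saturated chain carbon bound to a sulfur. Among the compounds with values here, the only measured step at this place is a 1.1-fold lower number from compound 1 to compound 2 (0.04 log units; within the scatter), which was within the scatter, so no step beyond the scatter is expected in this assay for compound 3, that is a 1.1-fold higher number from compound 2 to compound 3 (0.02 log units; within the scatter). Compound 3 is therefore estimated at 9500 nM, within 4500 nM to 20000 nM.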

Compound 3, half-maximal inhibitory concentration: 6020 nM
Compound 3: the middle estimate sits 1.6-fold (0.20 log units) above what was measured; the measured number falls inside the stated range.
By their numbers in this assay, from the lowest: compounds 3, 2 and 1 (each within the scatter of the next).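

In this assay, ethyl in place of 3-methylphenyl on a saturated chain carbon bound to a sulfur gives a 1.5-fold lower number from compound 2 to compound 3 (0.18 log units; within the scatter), so removing the aromatic ring here produces no separation beyond the scatter. Methyl in place of hydrogen on a saturated chain carbon, two bonds along the chain from a sulfur, gives a 1.7-fold lower number from compound 1 to compound 3 (0.22 log units; within the scatter), also within the scatter. Nothing available explains these values. Going by these compounds, whether an amine, a carboxylic acid or a longer chain at this position would give a step beyond the scatter remains open.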